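The compounds below may be only part of what the source reports. "The series", "measured", "known", "first", "only" and "open" are said of these compounds alone.

Compound 1 `COc1cccc(/C=C/C(=O)c2c(OC)cc(OC)cc2OC)c1` is one of three chalcone-type compounds measured in a functional assay on HCT-116 cells (Homo sapiens), read by fluorescence and BrdU incorporation, with a stated time of 48 h, tested at 25 uM (on this read-out lower numbers stand for a stronger effect and higher numbers for a weaker effect at the one concentration tested), where compound 1 gives 0.6%. Its two companions are compound 2 `COc1cc(OC)c(C(=O)/C=C/c2ccccc2SC)c(OC)c1`, which in this assay gives 0.5%, and compound 3 `COc1cc(OC)c(C(=O)/C=C/c2ccccc2)c(OC)c1`, which in this assay gives 2.6%. Compound 1 sits among numbers that all lie within the usual scatter of one another: the step of a number 0.1 percentage points lower from compound 1 to compound 2 (within the scatter) and the step of a number 2 percentage points higher from compound 1 to compound 3 (within the scatter) both fall inside it, as does the step of a number 2.1 percentage points higher from compound 2 to compound 3 (within the scatter).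

The next compound is compound 4 `COc1cc(OC)c(C(=O)/C=C/c2ccc(F)cc2)c(OC)c1`, which is still to be tested. It differs from compound 1 in one place: 4-fluorophenyl in place of 3-methoxyphenyl on a double-bonded chain carbon bound to a double-bonded chain carbon.

Going by the values given here, the steps that bear on this change are those in which the ring on the double-bonded chain carbon was altered, namely a number 0.1 percentage points lower from compound 1 to compound 2 (within the scatter) and a number 2 percentage points higher from compound 1 to compound 3 (within the scatter), and neither moved the number beyond the scatter. Among the compounds with values here, compound 4 is therefore expected to show no step in this assay beyond the scatter, an expected step of a number 0.9 percentage points higher from compound 1 to compound 4 (within the scatter). Compound 4 is estimated to give 1.5% in this assay, within a range from 0% to 10%.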

Compound 4, a percentage reported as activity, at one concentration (the size of the read-out at that concentration, not a potency): 0.7%
The estimate for compound 4 lay 0.8 percentage points above the measured number; measured number inside the range.
By their numbers in this assay, from the lowest: compounds 2, 1, 4 and 3 (each within the scatter of the next).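

In this assay, 4-fluorophenyl in place of 3-methoxyphenyl on a double-bonded chain carbon gives a number 0.1 percentage points higher from compound 1 to compound 4 (within the scatter) and, set against the methylsulfanyl compound, a number 0.2 percentage points higher from compound 2 to compound 4 (within the scatter) as well. Fluoro in place of hydrogen on an aromatic carbon gives a number 1.9 percentage points lower from compound 3 to compound 4 (within the scatter) here, so a fluorine joins methoxy and methylsulfanyl as a substituent on this ring that shifts the number by no more than the scatter, and no order among the four compounds can be read. No measurement is available that would explain this flat picture.

The compounds shown leave open whether any substituent on this ring can move the number beyond the scatter at the one concentration tested. An amine or a carboxylic acid on this ring would test that, and so would a longer chain in this place.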